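Aryl Replacement at the Core Leaves Displacement Unchanged

The source may report more compounds than this note shows. Statements on the series, on what has been measured and on what is new or still open speak of the compounds shown alone.

Compound 1 `CC(C)(C)Cc1c(-c2ccoc2)sc(N)c1C(=O)c1ccc(Cl)cc1`: 1%
Compound 2 `CC(C)(C)Cc1c(-c2ccncc2)sc(N)c1C(=O)c1ccc(Cl)cc1`: 6%
Compound 3 `CC(C)(C)Cc1c(-c2ccc(Cl)cc2)sc(N)c1C(=O)c1ccc(Cl)cc1`: 1%

In an assay on CHO cells for displacement of a labelled ligand from adenosine receptor A3 (Homo sapiens), read by scintillation counting, tested at 10 uM (on this read-out higher numbers stand for more inhibition at the one concentration tested (going by the name of the read-out) and lower numbers for less inhibition), compound 3 stands level with compound 1, the two together the lowest of the three numbers; the step of a number 5 percentage points lower from compound 2 to compound 3 (within the scatter) is within the scatter, as is no change at the digits printed from compound 1 to compound 3 (within the scatter). Compound 4 `COc1ccccc1-c1sc(N)c(C(=O)c2ccc(Cl)cc2)c1CC(C)(C)C` differs from compound 3 in one place: 2-methoxyphenyl in place of 4-chlorophenyl on an aromatic carbon. The measured steps that bear on this are the two replacements on the same aromatic carbon, no change at the digits printed from compound 1 to compound 3 (within the scatter) and a number 5 percentage points lower from compound 2 to compound 3 (within the scatter), neither beyond the scatter; the step of a number 5 percentage points higher from compound 1 to compound 2 (within the scatter) is likewise within it. Since every aryl group tried there gave a flat read-out, no step beyond the scatter is expected in this assay for compound 4, the expected step being a number 2 percentage points higher from compound 3 to compound 4 (within the scatter). Compound 4 is estimated at 3%, within 0% to 15%.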

Compound 4, a percentage reported as inhibition, at one concentration (the size of the read-out at that concentration, not a potency): 1%
For compound 4 the middle estimate is 2 percentage points above the measured one; the measured number falls inside the stated range.
By their numbers in this assay, from the lowest: compounds 1, 3, 4 and 2 (each within the scatter of the next).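

In this assay the 2-methoxyphenyl group gives no change at the digits printed from compound 3 to compound 4 (within the scatter), alongside no change at the digits printed from compound 1 to compound 4 (within the scatter) and a number 5 percentage points lower from compound 2 to compound 4 (within the scatter). The flat read-out at this carbon next to the ring sulfur therefore extends to a phenyl ring with a methoxy group, which adds a hydrogen-bond acceptor that 4-chlorophenyl lacks. No evidence at hand explains this result.

The compounds shown leave open whether an aminomethyl or carboxylic acid group on this aryl ring would change the number. They also leave open whether a shorter chain in place of the neopentyl group would do so.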